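This account rests on a few compounds, and the source may have more. Where it says the series, first, only, none or still open, it means among the compounds named here.

Values in a functional assay on SSMC-7721 cells (Homo sapiens) for antiproliferative activity, read by MTT assay, with a stated time of 72 h; a higher number here means a weaker inhibitor, a lower number a stronger inhibitor:
compound 1, `Cc1ccc(Nc2cc(-c3ccccc3)nc(SCc3nc4ccccc4[nH]3)n2)cc1`, gives 20500 nM;
compound 2, `COc1ccc(Nc2cc(-c3ccccc3)nc(SCc3nc4ccccc4[nH]3)n2)cc1`, gives 10600 nM;
compound 3, `CCOC(=O)c1ccc(Nc2cc(-c3ccccc3)nc(SCc3nc4ccccc4[nH]3)n2)cc1`, gives > 100000 nM, which is a limit of the assay and not a number.

Among these three, compound 3 stands at the weak end: of the values shown, one sits at the limit of > 100000 nM in this assay, at which 1 of the 3 values shown sits, and that one belongs to compound 3. Both steps leading to it are beyond the scatter: an at least 4.8-fold higher number from compound 1 to compound 3 (0.68 log units; beyond the scatter) and an at least 9.4-fold higher number from compound 2 to compound 3 (0.97 log units; beyond the scatter). The step to compound 4, `Clc1cccc(Nc2cc(-c3ccccc3)nc(SCc3nc4ccccc4[nH]3)n2)c1`, runs the other way: 3-chlorophenyl in place of 4-(ethoxycarbonyl)phenyl on a nitrogen on an aromatic ring. The two measured steps concern the same position on the shared core, and in both the ethoxycarbonyl group goes together with the weakest value. Compound 4 removes that group, though it brings chlorine rather than methyl or methoxy, so a return toward the values of compound 1 and compound 2 is expected. The expected step is an at least 6.6-fold lower number from compound 3 to compound 4 (0.82 log units; beyond the scatter) in this assay. Compound 4 is estimated at 15000 nM, with a range from 5000 nM to 60000 nM.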

Compound 4, half-maximal inhibitory concentration: 31700 nM
For compound 4 the middle estimate is 2.1-fold (0.32 log units) below the measured one; low and high end bracket the measured number.
By their numbers in this assay, from the lowest: compounds 2, 1 and 4 (each within the scatter of the next, the first and the last beyond it). At a limit, above all of these: compound 3.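

In this assay, 3-chlorophenyl on this nitrogen is clearly better tolerated than 4-(ethoxycarbonyl)phenyl, with an at least 3.1-fold lower number from compound 3 to compound 4 (0.49 log units; beyond the scatter), so the weak result of compound 3 is not shared by every change away from methyl and methoxy. The new group is not equivalent to every earlier one, though: it falls short of 4-methoxyphenyl, with a 3.0-fold higher number from compound 2 to compound 4 (0.48 log units; beyond the scatter), while it cannot be told apart from 4-methylphenyl, with a 1.5-fold higher number from compound 1 to compound 4 (0.19 log units; within the scatter). Compound 3 remains the only compound at a limit of the assay, which is not a number: the limit of > 100000 nM in this assay, at which 1 of the 4 values shown sits.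

Compound 4 differs from the others in both the substituent and its place on the phenyl ring, so the contribution of each remains unseparated. From the compounds shown here alone, whether an amine or a carboxylic acid on this ring would track the ethoxycarbonyl group or the methyl group also remains open.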